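This account rests on a few compounds, and the source may have more. Where it says the series, first, only, none or still open, it means among the compounds named here.

Working notes on three compounds sharing one core, all measured in an ADME assay on THP-1 cells (Homo sapiens) for cytotoxicity; a higher number here means a weaker inhibitor, a lower number a stronger inhibitor. Compound 1 `COc1ccccc1-c1nnc(-c2ccc(C(=O)N/N=C/c3cccc([N+](=O)[O-])c3)cc2)o1` gives 119000 nM, the second highest of the three numbers. Compound 3 `COc1ccccc1-c1nnc(-c2ccc(C(=O)N/N=C/c3cccc(O)c3O)cc2)o1` gives 102000 nM. The step between them is a 1.2-fold lower number from compound 1 to compound 3 (0.07 log units; within the scatter), within the scatter. Compound 2 `COc1ccccc1-c1nnc(-c2ccc(C(=O)N/N=C/c3ccc(F)cc3)cc2)o1` gives 427000 nM. Here the step of a 3.6-fold higher number from compound 1 to compound 2 (0.55 log units; beyond the scatter) is modest but beyond the scatter, as is a 4.2-fold lower number from compound 2 to compound 3 (0.62 log units; beyond the scatter).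

Compound 4 `COc1ccccc1-c1nnc(-c2ccc(C(=O)N/N=C/c3ccc(O)cc3)cc2)o1` is not yet measured and differs from compound 1 as follows: 4-hydroxyphenyl in place of 3-nitrophenyl on a carbon with a double bond to nitrogen. Both measured steps from compound 1 bear on this. Replacing the 3-nitrophenyl with 4-fluorophenyl gave a 3.6-fold higher number from compound 1 to compound 2 (0.55 log units; beyond the scatter); replacing it with 2,3-dihydroxyphenyl gave a 1.2-fold lower number from compound 1 to compound 3 (0.07 log units; within the scatter). The entering 4-hydroxyphenyl carries a hydroxy group as the 2,3-dihydroxyphenyl does, so the nearer precedent is the step within the scatter, and no step beyond the scatter is expected in this assay, in either direction. Compound 4 is therefore estimated at 110000 nM, with a range from 50000 nM to 250000 nM. This estimate means an expected step of a 1.1-fold lower number from compound 1 to compound 4 (0.03 log units; within the scatter).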

Compound 4, half-maximal inhibitory concentration: 261000 nM
For compound 4 the middle estimate is 2.4-fold (0.38 log units) below the measured one; measured number outside the range, above it.
By their numbers in this assay, from the lowest: compounds 3 and 1 (each within the scatter of the next); then compounds 4 and 2 (each within the scatter of the next).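

In this assay, sharing a hydroxy group does not make the 4-hydroxyphenyl equivalent to the 2,3-dihydroxyphenyl at this place on the carbon with a double bond to nitrogen (a 2.6-fold higher number from compound 3 to compound 4 (0.41 log units; beyond the scatter)), and the 4-hydroxyphenyl also separates from the 3-nitrophenyl (a 2.2-fold higher number from compound 1 to compound 4 (0.34 log units; beyond the scatter)). Hydroxy in place of fluoro on the aromatic carbon gives a step within the scatter (a 1.6-fold lower number from compound 2 to compound 4 (0.21 log units; within the scatter)), so the 4-fluorophenyl and 4-hydroxyphenyl compounds form one pair, and the 3-nitrophenyl and 2,3-dihydroxyphenyl compounds form the other. No measurement at hand accounts for this split.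

The compounds shown leave open whether the split follows the identity of the group or where it sits on the phenyl ring. A 3-hydroxyphenyl, or a phenyl carrying an amine or a carboxylic acid, would test this further.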